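Dihydroxy series: cytotoxicity in HOS cells, fluoro step

The source may report more compounds than this note shows. Statements on the series, on what has been measured and on what is new or still open speak of the compounds shown alone.

Measured so far:
compound 1 `O=C1c2ccc(O)c(O)c2C(=O)N1Cc1cccc(Cl)c1` gives 13300 nM
compound 2 `O=C1c2c(ccc(O)c2O)CN1Cc1ccc(F)c(Cl)c1` gives 6870 nM
compound 3 `O=C1c2ccc(O)c(O)c2C(=O)N1Cc1ccc(F)c(Cl)c1` gives 9540 nM

Three compounds have been run in an ADME assay on HOS cells (Homo sapiens) for cytotoxicity; on this read-out lower numbers stand for stronger inhibition and higher numbers for weaker inhibition. Compound 1 and compound 3 share one core; compound 2 has a different core, and the difference between the two cores is not broken down here. Compound 2 and compound 3 lie within the scatter of each other, as do compound 2 and compound 1.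

From compound 1 to compound 3 the change is fluoro in place of hydrogen on an aromatic carbon and the step is a 1.4-fold lower number from compound 1 to compound 3 (0.14 log units; within the scatter).

Compound 4 `O=C1c2c(ccc(O)c2O)CN1Cc1cc(Cl)c(F)cc1F` is not yet measured. Against compound 2 the change is fluoro in place of hydrogen on an aromatic carbon. It is the same kind of change as from compound 1 to compound 3, but the surroundings differ: there the entering fluoro sits ortho to a chloro group and para to a large group; here it sits ortho to a large group, meta to a fluoro group and para to a chloro group.

In this assay a step of about a 1.2-fold lower number from compound 2 to compound 4 (0.10 log units; within the scatter) is expected from compound 2 to compound 4, resting on the earlier step of a 1.4-fold lower number from compound 1 to compound 3 (0.14 log units; within the scatter), which stayed within the scatter. Compound 4 is thus estimated at 5500 nM, with 2500 nM to 12000 nM as the likely range.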

Compound 4, half-maximal inhibitory concentration: 8380 nM
Compound 4: the middle estimate sits 1.5-fold (0.18 log units) below what was measured, and the stated range covers the measured number.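

In this assay, fluoro in place of hydrogen on an aromatic carbon gives a 1.2-fold higher number from compound 2 to compound 4 (0.09 log units; within the scatter). Set beside the earlier step on the other core, the new step cannot be told apart from it: the same change on two cores in this assay, a 1.4-fold lower number (0.14 log units; within the scatter) from compound 1 to compound 3 and a 1.2-fold higher number (0.09 log units; within the scatter) from compound 2 to compound 4, 1.7-fold (0.23 log units) apart, within the scatter of two such steps

Among these compounds, on these two pairs, the change therefore carries from one core to the other with no step beyond the scatter on either core, but this shows only that neither core gives a clear response to this change in this assay. It does not show that the two cores respond alike in any finer sense, that the step has a direction, or that a step beyond the scatter would carry over, and the entering fluoro also sits in different surroundings in the two pairs.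

As far as these compounds go, the groups varied here are limited to fluoro and chloro, so it remains open whether an amine, a carboxylic acid or a longer chain at this place would move the number beyond the scatter. From the compounds shown here alone, whether such a step would then hold on both cores also remains open.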